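The compounds below may be only part of what the source reports. "The series", "measured", "known", "first", "only" and "open" are said of these compounds alone.

Measured so far:
- compound 1, `COc1ccc(-c2ccc(NC3=CC(=O)c4ncncc4C3=O)cc2)cc1`: 2100 nM
- compound 2, `COc1ccc(NC2=CC(=O)c3ncncc3C2=O)cc1OC`: 1800 nM

Both compounds were tested in a functional assay on MIA PaCa-2 cells (Homo sapiens) for cytotoxicity, read by MTT assay, with a stated time of 72 h; on this read-out lower numbers stand for stronger inhibition and higher numbers for weaker inhibition. On that read-out compound 1 gives 2100 nM, the higher of the two numbers, and compound 2 gives 1800 nM; the gap between them lies within the usual scatter of repeated measurements, so the two values cannot be told apart with confidence.

The next compound, compound 3, `O=C1C(Nc2ccc(Oc3ccccc3)cc2)=CC(=O)c2ncncc21`, keeps the shared core and the attached aniline ring but changes the group on that ring: phenoxy in place of 4-methoxyphenyl on an aromatic carbon. In plain words, phenoxy takes the place of 4-methoxyphenyl on an aromatic carbon, para to a large group. Among the measured compounds shown here, no step between two measured compounds covers this kind of exchange, so there is nothing directly comparable to lean on.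

Given that the two measured compounds sit so close together, the step from compound 1 to compound 3 in this assay is expected to be small, a 1.2-fold higher number from compound 1 to compound 3 (0.08 log units; within the scatter), probably no larger than the scatter itself. Compound 3 is therefore estimated at 2500 nM, within a range of 800 nM to 8000 nM.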

Compound 3, half-maximal inhibitory concentration: 3700 nM
Beside the measured number, compound 3's estimate is 1.5-fold (0.17 log units) below it; low and high end bracket the measured number.
By their numbers in this assay, from the lowest: compounds 2, 1 and 3 (each within the scatter of the next, the first and the last beyond it).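

In this assay, among the compounds shown here, phenoxy in place of 4-methoxyphenyl on an aromatic carbon, para to a large group, gives a 1.8-fold higher number from compound 1 to compound 3 (0.25 log units; within the scatter), and this is the first step that can be read between two compounds differing in one place. Both groups hold one six-membered aromatic ring of carbon only and one oxygen, though the oxygen is placed differently in each, and this rearrangement produces no change that can be separated from the ordinary spread of repeated measurements, so this position allows the exchange without a clear gain or loss on this read-out. No independent measurement bears on this result, so what lies behind it cannot be said.

On these data alone, it remains open whether a group of a different kind in the same place, such as an amine, a carboxylic acid or a longer alkyl chain, would shift the number beyond that spread. The compounds shown also cannot tell whether a plain phenyl or a benzyl group would behave like phenoxy and 4-methoxyphenyl, which would show whether the oxygen matters here at all.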